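A few compounds are considered here, and "the series" means these few. Any claim that something is new, unique, unknown or untested is made for them only; others in the source may bear on it.

The measured compounds:
Compound 1 `CCOC(=O)C1(C(=O)NCc2ccc(C)cc2)CC1c1cc(OC)c(OC)c(OC)c1` gives 33200 nM; 25600 nM (2 entries) in a functional assay on HeLa cells (Homo sapiens) for cytotoxicity, read by MTT assay, with a stated time of 48 h; on this read-out higher numbers stand for weaker inhibition and lower numbers for stronger inhibition.
Compound 2 `COc1cc([C@H]2C[C@@]2(CO)C(=O)NCc2ccc(C)cc2)cc(OC)c1OC` gives > 100000 nM in this assay, which is a limit of the assay rather than a number.
Compound 3 `CCOC(=O)[C@]1(C(=O)NCc2ccc(C)cc2)C[C@H]1c1cc(OC)c(OC)c(OC)c1` gives 28500 nM in this assay.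

Within the data shown here, compound 3 thus stands as the only single number among the three entries; compound 1 has two close entries (the several entries of compound 1 in this assay, 33200 nM; 25600 nM (2 entries)), and compound 2 sits at a limit (the limit of > 100000 nM in this assay, at which 1 of the 3 values shown sits). Compound 4 `COc1cc([C@@H]2C[C@]2(CO)C(=O)NCc2ccc(C)cc2)cc(OC)c1OC` differs from compound 3 in one place: hydroxymethyl in place of ethoxycarbonyl on a saturated ring carbon. Compound 2 also bears hydroxymethyl and reaches only a limit in this assay (the limit of > 100000 nM in this assay, at which 1 of the 3 values shown sits), so a step toward weaker inhibition, possibly again only a limit, is expected. Compound 4 is expected to give about 100000 nM, between 40000 nM and 300000 nM, an expected 3.5-fold higher number from compound 3 to compound 4 (0.55 log units; beyond the scatter).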

Compound 4, half-maximal inhibitory concentration: 17400 nM
The estimate for compound 4 lay 5.7-fold (0.76 log units) above the measured number; the whole stated range lies above it.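

Putting hydroxymethyl in place of ethoxycarbonyl on this saturated ring carbon gives a 1.6-fold lower number from compound 3 to compound 4 (0.21 log units; within the scatter) in this assay, so this change alone shows no clear effect. Compound 2 gives > 100000 nM, which is a limit of the assay and not a number. Its mirror image still shows a clear difference, an at least 5.7-fold lower number from compound 2 to compound 4 (0.75 log units; beyond the scatter), so the arrangement in space matters here: the fact that compounds 2 and 4 differ only in the configuration as drawn

From the compounds shown here alone, whether the ethoxycarbonyl compounds depend on configuration in the same way remains open. So does how an amine or a carboxylic acid on this carbon would compare.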